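A ring exchange on a long-lived pair

This account rests on a few compounds, and the source may have more. Where it says the series, first, only, none or still open, it means among the compounds named here.

Compound 1 `Cn1nncc1-c1cnn([C@H](CC2CC2)c2ccc(-c3c(-n4cnnn4)ccc(Cl)c3F)c[n+]2[O-])c1`: > 3 h (a limit)
Compound 2 `COCC[C@H](c1ccc(-c2c(-n3cnnn3)ccc(Cl)c2F)c[n+]1[O-])n1cc(-c2cnnn2C)cn1`: 2.83 h

The values come from an ADME assay on microsomes from liver (Homo sapiens) for metabolic stability; a lower number here means that the compound disappears faster, a higher number that the compound lasts longer. For compound 1 the result is only a limit, > 3 h. Among the measured compounds shown here, compound 2, at 2.83 h, holds the only actual number. Compound 3 `COCC[C@H](c1ccc(-c2c(-n3cc(Cl)nn3)ccc(Cl)c2F)c[n+]1[O-])n1cc(-c2cnnn2C)cn1` carries 4-chloro-1H-1,2,3-triazol-1-yl in place of 1H-tetrazol-1-yl on an aromatic carbon. For the measured compounds named here, the one measured step, an at least 1.0-fold lower number from compound 1 to compound 2 (0.02 log units; that floor lies within the scatter), lies within the scatter and concerns the chain, not this place, so it gives no size for this change. No shift beyond the scatter is therefore expected in this assay, and the expected step is a 1.1-fold lower number from compound 2 to compound 3 (0.05 log units; within the scatter). The estimate for compound 3 is 2.5 h, within an expected range of 1.2 h to 4.5 h.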

Compound 3, half-life: 0.9 h
Compound 3: middle estimate off by 2.8-fold (0.44 log units), on the high side; measured number below the stated range.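

In this assay, this aromatic carbon responds to a single change where the chain step gave only a floor within the scatter: 4-chloro-1H-1,2,3-triazol-1-yl in place of 1H-tetrazol-1-yl gives a 3.1-fold lower number from compound 2 to compound 3 (0.50 log units; beyond the scatter). The ring on this carbon therefore matters for how long the compound lasts. The data shown offer no reason for this drop.

Going by these compounds, whether the ring exchange or the chlorine accounts for it stays open, as does how 1H-1,2,3-triazol-1-yl without chlorine would behave here. The same exchange on the cyclopropyl chain of compound 1 is also an open question.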